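Sulfonamide in Place of Glycinamide on the Amine Nitrogen

The source may hold more compounds than are shown below. What is called first, only, known or untested is meant among the compounds shown, and "the series" means these compounds.

Of the compounds shown here, three sharing one core have been measured in an assay on isolated protein for displacement of a labelled ligand from 5-hydroxytryptamine receptor 6 (Homo sapiens); on this read-out lower numbers stand for stronger inhibition and higher numbers for weaker inhibition. Compound 1 `CN(C)CC1CCCc2cc(S(=O)(=O)c3ccccc3)ccc21` gives 0.0631 nM. Compound 2 `NC[C@@H]1CCCc2cc(S(=O)(=O)c3cn[nH]c3)ccc21` gives 2 nM. Compound 3 `NC(=O)CNC[C@@H]1CCCc2cc(S(=O)(=O)c3cccc(F)c3)ccc21` gives 0.1 nM. Among these three numbers compound 3 stands second highest; its value and that of compound 1 lie within the scatter of each other, so no order between them can be read, while compound 2 gives a higher number than compound 3 by a margin well beyond the scatter.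

The next compound, compound 4 `CS(=O)(=O)NC[C@@H]1CCCc2cc(S(=O)(=O)c3cccc(F)c3)ccc21`, differs from compound 3 in a single place: methylsulfonyl in place of carbamoylmethyl on an amine nitrogen. The same core and the same fluorophenyl sulfone remain; only the group on the amine nitrogen is exchanged, carbamoylmethyl leaving and methylsulfonyl entering.

Going by the values given here, no measured pair in this set shows exactly this exchange, so the size of its effect cannot be read from a neighbouring step. The expectation for compound 4 in this assay is a move toward a higher number, with the step from compound 3 to compound 4 estimated at a 10-fold higher number from compound 3 to compound 4 (1.00 log units; beyond the scatter). Compound 4 is therefore expected to give about 1 nM, with a plausible range from 0.2 nM to 8 nM.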

Compound 4, inhibition constant: 0.2 nM
Beside the measured number, compound 4's estimate is 5.0-fold (0.70 log units) above it; measured number inside the range.
By their numbers in this assay, from the lowest: compounds 1, 3 and 4 (each within the scatter of the next, the first and the last beyond it); then compound 2.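

In this assay, going by these compounds alone, putting methylsulfonyl in place of carbamoylmethyl on the amine nitrogen gives a 2.0-fold higher number from compound 3 to compound 4 (0.30 log units; within the scatter), so no order can be read between the two, and this is the first pair in the set that differs in one place only. The group on that nitrogen goes from 1 hydrogen-bond donor and 1 hydrogen-bond acceptor to 0 hydrogen-bond donors and 2 hydrogen-bond acceptors, at 4 heavy atoms each, and for this one pair the read-out does not separate the two groups. Nothing available accounts for how close the two values lie.

The compounds shown leave open what an acetyl group, a longer sulfonyl chain such as ethylsulfonyl, or a carboxylic acid in place of the amide end of carbamoylmethyl would give on this nitrogen in this assay. Within the data shown here, they also leave open whether the same exchange would behave alike with a group other than the fluorophenyl on the sulfone, such as the one carried by compound 2.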